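One Aryl Swap Against Three Values at the Limit

The compounds below may be only part of what the source reports. "The series", "measured", "known", "first", "only" and "open" are said of these compounds alone.

Compound 1 `O=[N+]([O-])c1cn2c(n1)OCC(COc1ccc(OC(F)(F)F)cc1)C2` gives > 128000 nM in an ADME assay on Vero cells (Chlorocebus sabaeus) for cytotoxicity, with a stated time of 72 h (on this read-out lower numbers stand for stronger inhibition and higher numbers for weaker inhibition), a limit of the assay rather than a number.
Compound 2 `O=[N+]([O-])c1cn2c(n1)OC[C@@H](COc1ccc(OC(F)(F)F)cc1)C2` gives > 128000 nM in this assay, again a limit.
Compound 3 `O=[N+]([O-])c1cn2c(n1)OC[C@H](COc1ccc(OC(F)(F)F)cc1)C2` gives > 128000 nM in this assay, also a limit.

Compound 1 therefore stands at the upper limit of this assay, and so do the two other measured compounds, as the limit of > 128000 nM in this assay, at which 3 of the 3 values shown sit, records. The steps a step that the two limits leave unreadable from compound 1 to compound 2 and a step that the two limits leave unreadable from compound 1 to compound 3 rest on the fact that one of compounds 1 and 2 is drawn with a defined configuration and the other without, at the place where they differ and (the fact that one of compounds 1 and 3 is drawn with a defined configuration and the other without, at the place where they differ); the step that the two limits leave unreadable from compound 2 to compound 3 rests on (the fact that compounds 2 and 3 differ only in the configuration as drawn). None of the three is readable, and none concerns the change now in question.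

Compound 4 `O=[N+]([O-])c1cn2c(n1)OCC(COc1ccc(-c3ccc(F)cc3)cc1)C2` differs from compound 1 by 4-fluorophenyl in place of trifluoromethoxy on an aromatic carbon. For the measured compounds named here, no measured step bears on this change; the three measured compounds differ only in drawn configuration. Compound 4 is therefore expected to sit at or near the same limit, with the step of an at least 1.2-fold lower number from compound 1 to compound 4 (0.10 log units; that floor lies within the scatter) expected to be small or unreadable. The estimate for compound 4 is 100000 nM, within 30000 nM to 200000 nM.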

Compound 4, half-maximal inhibitory concentration: > 128000 nM
Compound 4: only a limit was reported; the forecaster's own chance of this, stated with the estimate: 60%; middle value at least 1.2-fold (0.10 log units) from the limit.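

In this assay compound 4 gives > 128000 nM, a limit and not a number. For the compounds shown here, compound 1 also sits at a limit, so no step between compound 1 and compound 4 can be read. The compounds shown leave open whether 4-fluorophenyl in place of trifluoromethoxy changes this read-out at all.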